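Hydroxyethoxy analogue of the cyanomethoxy lactam

A few compounds are considered here, and "the series" means these few. Any claim that something is new, unique, unknown or untested is made for them only; others in the source may bear on it.

Two members of this series have been measured in an assay on isolated protein for inhibition of mitogen-activated protein kinase kinase kinase 11 (Homo sapiens), tested at 1 uM; on this read-out higher numbers stand for more inhibition at the one concentration tested (going by the name of the read-out) and lower numbers for less inhibition. Compound 1 `O=C1NCc2c1c1c(c3c2c2ccccc2n3CCO)CCc2cc(OC3CCCCC3)ccc2-1` gives 4%. Among the compounds with values here, compound 2 `N#CCOc1ccc2c(c1)CCc1c-2c2c(c3c4ccccc4n(CCO)c13)CNC2=O` gives 8%, and the only measured step, a number 4 percentage points higher from compound 1 to compound 2 (within the scatter), leaves compound 2 on the same footing as compound 1, both low on this read-out at the concentration tested.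

Compound 3 `O=C1NCc2c1c1c(c3c2c2ccccc2n3CCO)CCc2cc(OCCO)ccc2-1` differs from compound 2 in one place: hydroxymethyl in place of cyano on a saturated chain carbon bound to an oxygen on an aromatic ring. Within the data shown here, no measured step bears on this exchange; the single step from compound 1 to compound 2 altered the group on the aromatic oxygen in a different way and was itself within the scatter. Both measured values sit near the floor of this assay, so a step beyond the scatter is not expected in either direction, and the step of a number 1 percentage points lower from compound 2 to compound 3 (within the scatter) is estimated accordingly.

Compound 3 is therefore expected to give 7% in this assay, with a range of -5% to 20%.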

Compound 3, a percentage reported as inhibition, at one concentration (the size of the read-out at that concentration, not a potency): 46%
The estimate for compound 3 lay 39 percentage points below the measured number, and the stated range ends below it.
By their numbers in this assay, from the lowest: compounds 1 and 2 (each within the scatter of the next); then compound 3.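

In this assay the group on the oxygen on the aromatic ring can clearly move the number: hydroxymethyl in place of cyano on the saturated chain carbon gives a number 38 percentage points higher from compound 2 to compound 3 (beyond the scatter) even though the exchange of cyclohexyl for cyanomethyl stayed within the scatter. With 2-hydroxyethyl in place of cyclohexyl the series shows a number 42 percentage points higher from compound 1 to compound 3 (beyond the scatter) and compound 3 therefore stands apart from both compound 1 and compound 2, while those two cannot be told apart. Nothing shown here accounts for this rise.

Going by these compounds, it remains open whether the gain depends on the terminal hydroxyl or on the chain carrying it; a 2-methoxyethyl group, a 2-aminoethyl group or a longer 3-hydroxypropyl chain on the aromatic oxygen would separate these. A reading at one concentration also leaves the potency of compound 3 open.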